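This account rests on a few compounds, and the source may have more. Where it says the series, first, only, none or still open, it means among the compounds named here.

Compound 1 `N#Cc1ccc(NC(=O)c2cc(F)ccc2O)cc1` and compound 2 `N#Cc1ccc(NC(=O)c2ccc(F)cc2O)cc1` are built from the same atoms joined differently; the difference between the two cores is not broken down here. In a functional assay on KG-1 cells (Homo sapiens) for cytotoxicity, read by luminescence and CellTiter-Glo, with a stated time of 3 days (on this read-out lower numbers stand for stronger inhibition and higher numbers for weaker inhibition), compound 1 gives 2670 nM, and compound 2 gives 3150 nM, two numbers that lie within the usual scatter of each other. Compound 3 `N#Cc1ccc(NC(=O)c2cc(Br)ccc2O)cc1` is compound 1 with a single change: bromo in place of fluoro on an aromatic carbon. In this assay compound 3 gives 1290 nM; the step is a 2.1-fold lower number from compound 1 to compound 3 (0.32 log units; beyond the scatter).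

Compound 4 `N#Cc1ccc(NC(=O)c2ccc(Br)cc2O)cc1` has not yet been measured. It stands to compound 2 as compound 3 stands to compound 1: bromo in place of fluoro on an aromatic carbon. The surroundings are not identical, though. In compound 3 the bromo sits meta to a large group and para to a hydroxy group, whereas in compound 4 it sits meta to a hydroxy group and para to a large group, so this is the same kind of change rather than the same change. For the measured compounds named here, the expectation for compound 4 rests on the one measured example of this change, a 2.1-fold lower number from compound 1 to compound 3 (0.32 log units; beyond the scatter), applied to the value of compound 2, 3150 nM. Compound 4 is therefore expected to reach about 1500 nM in this assay, most likely between 800 nM and 2900 nM. For compound 4 this estimate means a 2.1-fold lower number from compound 2 to compound 4 (0.32 log units; beyond the scatter), a step expected to be about the size seen once before.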

Compound 4, half-maximal inhibitory concentration: 1450 nM
Compound 4: the middle estimate sits 1.0-fold (0.01 log units) above what was measured; low and high end bracket the measured number.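

In this assay, putting bromo in place of fluoro on the core of compound 2 gives a 2.2-fold lower number from compound 2 to compound 4 (0.34 log units; beyond the scatter), so this change now has a second measured example on a different core. The two examples agree in size, even though the bromo sits meta to a hydroxy group and para to a large group in compound 4 and the other way round in compound 3: the same change on two cores in this assay, a 2.1-fold lower number (0.32 log units; beyond the scatter) from compound 1 to compound 3 and a 2.2-fold lower number (0.34 log units; beyond the scatter) from compound 2 to compound 4, 1.0-fold (0.02 log units) apart, within the scatter of two such steps For these two cores, then, the change carries over with much the same size, but two pairs in a single cell read-out do not make a general rule, and they do not show why the number falls or whether the same step would appear on a third core.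

Among the compounds shown, only fluoro and bromo occupy this aromatic carbon, which leaves open what a chloro, a methyl, an amine or a carboxylic acid would do there on either core. Also open, on these data alone, is whether the step would keep its size if the nitrile or the hydroxy group were replaced by another group, such as a methoxy in place of the hydroxy.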